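The source may report more compounds than this note shows. Statements on the series, on what has been measured and on what is new or still open speak of the compounds shown alone.

Measured so far, in an assay on isolated protein for inhibition of thiosulfate sulfurtransferase (Homo sapiens), with a stated time of 60 min, in the absence of a further agent; a higher number here means a weaker inhibitor, a lower number a stronger inhibitor:
compound 1 `COc1c(Br)cccc1C(=O)Nc1ccc(Sc2nc3ccccc3s2)c(Cl)c1`: > 100000 nM
compound 2 `O=C(Nc1cccc(Cl)c1)c1cc(Br)cc(Br)c1O`: > 100000 nM
compound 3 `O=C(Nc1cccc(Cl)c1)c1cccc(Br)c1`: > 100000 nM

Each of these three values is a limit of the assay rather than a number. Compound 1 stands at that limit. Compounds 2 and 3 sit there as well, as the limit of > 100000 nM in this assay, at which 3 of the 3 values shown sit, shows. Among the measured compounds shown here, no step between measured compounds is available, so nothing yet tells how any change moves this assay.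

Compound 4 `O=C(Nc1ccc(Sc2nc3ccccc3s2)c(Cl)c1)c1cc(Br)ccc1O` has not been measured. It differs from compound 1 in one place: a group of 8 heavy atoms (6 carbon, 1 oxygen, 1 bromine; one six-membered aromatic ring of carbon only) in place of a group of 9 heavy atoms (7 carbon, 1 oxygen, 1 bromine; one six-membered aromatic ring of carbon only), on a carbonyl carbon. Compounds 2 and 3, whose values are also limits, offer no sign of a gain to lean on. The expected step that the limit leaves unreadable from compound 1 to compound 4 is therefore none beyond the scatter, most likely ending at the limit again. For compound 4 the estimate is 150000 nM, with a range from 30000 nM to 1000000 nM.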

Compound 4, half-maximal inhibitory concentration: > 100000 nM
Compound 4: only a limit was reported (the forecaster's own chance of this, stated with the estimate: 75%); the middle value lies beyond the limit too.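

Among the compounds shown here, compound 1 and compound 4 both stand at a limit of the assay rather than at a number, so no step between them can be read. The compounds shown leave open which structural change, if any, would give a measurable value in this assay.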